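This account rests on a few compounds, and the source may have more. Where it says the series, first, only, none or still open, it means among the compounds named here.

Measured compounds in this set:
Compound 1 `Cc1nn(C)c(Oc2ccc(F)cc2)c1/C=N\CCCCCCOc1cc2oc(=O)cc(C)c2cc1Cl`: in a functional assay on U-87MG ATCC cells for antiproliferative activity against U-87 MG (Homo sapiens), read by MTT assay, with a stated time of 72 h (on this read-out higher numbers stand for weaker inhibition and lower numbers for stronger inhibition), compound 1 gives 16700 nM
Compound 2 `Cc1nn(C)c(Oc2ccc(Cl)cc2)c1/C=N\CCCCCCOc1cc2oc(=O)cc(C)c2cc1Cl`: compound 2 gives 3850 nM
Compound 3 `Cc1nn(C)c(Oc2ccccc2Br)c1/C=N\CCCCCCOc1cc2oc(=O)cc(C)c2cc1Cl`: compound 3 gives 21800 nM

Compound 3 carries the highest number of the three. Its gap to compound 1, a 1.3-fold higher number from compound 1 to compound 3 (0.12 log units; within the scatter), lies within the scatter, so the two cannot be ordered; its gap to compound 2, a 5.7-fold higher number from compound 2 to compound 3 (0.75 log units; beyond the scatter), lies beyond it.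

Compound 4 `Cc1ccccc1Oc1c(/C=N\CCCCCCOc2cc3oc(=O)cc(C)c3cc2Cl)c(C)nn1C` differs from compound 3 by methyl in place of bromo on an aromatic carbon, on an aromatic carbon of a six-membered aromatic ring of carbon only, ortho to a large group.

Among the compounds with values here, none of the measured steps exchanges a halogen for a methyl. The step of a 4.3-fold lower number from compound 1 to compound 2 (0.64 log units; beyond the scatter) concerns chloro for fluoro within the 4-substituted phenoxy series; the steps of a 1.3-fold higher number from compound 1 to compound 3 (0.12 log units; within the scatter) and a 5.7-fold higher number from compound 2 to compound 3 (0.75 log units; beyond the scatter) concern the move from 4-fluorophenyl or 4-chlorophenyl to 2-bromophenyl. Within the data shown here, the bromo-to-methyl exchange of compound 4 therefore has no direct precedent here. On these data the expected step is a 1.1-fold lower number from compound 3 to compound 4 (0.04 log units; within the scatter), that is, none beyond the scatter, with wide uncertainty. Compound 4 is accordingly estimated at 20000 nM, with a range from 7000 nM to 60000 nM.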

Compound 4, half-maximal inhibitory concentration: 9610 nM
Estimate against measurement, compound 4: 2.1-fold (0.32 log units) above, within the range that was stated.
By their numbers in this assay, from the lowest: compound 2; then compounds 4, 1 and 3 (each within the scatter of the next, the first and the last beyond it).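

In this assay the change from 2-bromophenoxy to 2-methylphenoxy gives a 2.3-fold lower number from compound 3 to compound 4 (0.36 log units; beyond the scatter) and lies beyond the scatter. Within the data shown here, this is the first step here that changes only the group on the aromatic carbon ortho to a large group, and it shows that the read-out responds to bromo versus methyl with the place held fixed. The 2-methylphenyl compound still falls short of the 4-chlorophenyl compound, as a 2.5-fold higher number from compound 2 to compound 4 (0.40 log units; beyond the scatter) shows beyond the scatter, while a 1.7-fold lower number from compound 1 to compound 4 (0.24 log units; within the scatter) stays within the scatter, so compound 4 and compound 1 cannot be ordered. Nothing in the data on hand accounts for the difference between bromo and methyl at this place.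

From the compounds shown here alone, it remains open whether chloro, methoxy or an amino group at this place would sit with methyl or with bromo. Also open, going by these compounds, is how 4-methylphenyl and 4-bromophenyl would compare with their 2-substituted counterparts, which would separate the effect of the group from that of its place on the ring.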